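Swapping an Oxane Amide for a Pyridylmethyl Carbamate

The compounds below may be only part of what the source reports. "The series", "measured", "known", "first", "only" and "open" are said of these compounds alone.

Measured so far:
compound 1, `Cc1cc(C(=O)NCc2ccccc2)nn1Cc1cc(Cl)ccc1OCc1ccccc1`, 15 mL.min-1.g-1
compound 2, `Cc1cc(NC(=O)C2CCOCC2)nn1Cc1cc(Cl)ccc1OCc1ccccc1`, 9.1 mL.min-1.g-1

In an in vitro ADME assay on microsomes from liver (Rattus norvegicus) for metabolic stability (on this read-out higher numbers stand for fast clearance and lower numbers for slow clearance), compound 1 gives 15 mL.min-1.g-1. Compound 2 gives 9.1 mL.min-1.g-1 in this assay. The two numbers sit within the scatter of each other, the only step shown being a 1.6-fold lower number from compound 1 to compound 2 (0.22 log units; within the scatter).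

Compound 3, `Cc1cc(NC(=O)OCc2ccccn2)nn1Cc1cc(Cl)ccc1OCc1ccccc1`, differs from compound 2 by (pyridin-2-yl)methoxy in place of oxan-4-yl on a carbonyl carbon. For the measured compounds named here, no measured step touches this change, and the one step known was within the scatter. Compound 3 is therefore expected to show no step beyond the scatter, which means an expected 1.2-fold higher number from compound 2 to compound 3 (0.08 log units; within the scatter). The estimate for compound 3 is 11 mL.min-1.g-1, with a range from 5 mL.min-1.g-1 to 25 mL.min-1.g-1.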

Compound 3, intrinsic clearance in microsomes: 8.4 mL.min-1.g-1
Estimate against measurement, compound 3: 1.3-fold (0.12 log units) above; the range from low to high includes it.
By their numbers in this assay, from the lowest: compounds 3, 2 and 1 (each within the scatter of the next).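

Measured in this assay the swap of oxan-4-yl for (pyridin-2-yl)methoxy on this carbonyl carbon gives a 1.1-fold lower number from compound 2 to compound 3 (0.03 log units; within the scatter) and so shows that an aromatic ring can stand here without a step beyond the scatter. The wider swap from benzylcarbamoyl gives a 1.8-fold lower number from compound 1 to compound 3 (0.25 log units; within the scatter) and leaves all three compounds within the scatter of one another. Nothing available explains this result. From the compounds shown here alone, whether an amine such as piperidin-1-yl, a plain benzyloxy group or a longer chain on this carbonyl carbon would give a step beyond the scatter remains open.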